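A few compounds are considered here, and "the series" means these few. Any claim that something is new, unique, unknown or untested is made for them only; others in the source may bear on it.

Measured in a functional assay on PC-3 cells (Homo sapiens) for antiproliferative activity, read by sulforhodamine B assay, with a stated time of 48 h; a lower number here means a stronger inhibitor of growth, a higher number a weaker inhibitor of growth:
- compound 1 `O=C(NCCCNc1cc(-c2cn(-c3ccccc3)nc2-c2cccc(O)c2)ccn1)Nc1ccc(F)cc1`: 8920 nM
- compound 2 `O=C(NCCCNc1cc(-c2cn(-c3ccccc3)nc2-c2cccc(O)c2)ccn1)Nc1cccc(C(F)(F)F)c1`: 11200 nM

Among the compounds with values here, compound 1 has only one measured neighbour, and the two cannot be separated: the step is a 1.3-fold higher number from compound 1 to compound 2 (0.10 log units; within the scatter). Compound 3 `COc1cccc(-c2nn(-c3ccccc3)cc2-c2ccnc(NCCCNC(=O)Nc3ccc(F)cc3)c2)c1` keeps the rest of compound 1 but carries methyl in place of hydrogen on an oxygen on an aromatic ring, which is methyl in place of hydrogen on an oxygen on an aromatic ring, or 3-hydroxyphenyl to 3-methoxyphenyl. The measured step changes a different group, on an amide-type nitrogen, so it gives no direct guide to this change. No step beyond the scatter can be expected in either direction, though uncertainty remains wide. The expected result is a 1.1-fold higher number from compound 1 to compound 3 (0.05 log units; within the scatter). For compound 3 the estimated value is 10000 nM, with an expected range of 3500 nM to 30000 nM.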

Compound 3, concentration for total growth inhibition: > 37000 nM
Compound 3 ended at the assay's limit; the forecaster's own chance of this, stated with the estimate: 15%; middle value at least 3.7-fold (0.56 log units) away from the limit.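

Compound 3 sits at a limit, not at a measured number, in this assay: the limit of > 37000 nM in this assay, at which 1 of the 3 values shown sits.

Even so, the step is an at least 4.1-fold higher number from compound 1 to compound 3 (0.61 log units; beyond the scatter). It is the only step shown that lies beyond the scatter, so the hydroxy group of the 3-hydroxyphenyl is sensitive to a single added methyl, whereas the change on the amide-type nitrogen gave no separable difference.

On these data alone, the true size of this loss stays unknown, since only a limit is available. As far as these compounds go, it also remains open how an amine or a fluorine in place of the hydroxy would compare with compound 1.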